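Hydroxy-methylphenyl replacing dichlorophenyl on the pyridazinone core

The source may report more compounds than this note shows. Statements on the series, on what has been measured and on what is new or still open speak of the compounds shown alone.

Of the compounds shown here, three sharing one core have been measured in a functional assay on the whole organism (strain Wistar) for inhibition, with Rattus norvegicus as the target, read by paw edema, with stated times of 30 min and 5 h, at a dose of 0.05 mmol/kg by the oral route; a lower number here means less inhibition, a higher number more inhibition at the dose given (going by the name of the read-out). Compound 1 `COc1ccc(C2=NN(c3ccc(S(C)(=O)=O)cc3)C(=O)CC2)cc1` gives 68.4%, compound 2 `Cc1cc(O)ccc1C1=NN(c2ccc(S(C)(=O)=O)cc2)C(=O)CC1` gives 52.6%, and compound 3 `CS(=O)(=O)c1ccc(N2N=C(c3ccc(Cl)c(Cl)c3)CCC2=O)cc1` gives 34.2%. Compound 3 stands lowest of the three: compound 2 lies nearest, and the step of a number 18.4 percentage points lower from compound 2 to compound 3 (beyond the scatter) is beyond the scatter, while compound 1 lies furthest, with the step of a number 34.2 percentage points lower from compound 1 to compound 3 (beyond the scatter) also beyond the scatter.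

Compound 4 `Cc1ccc(O)c(C2=NN(c3ccc(S(C)(=O)=O)cc3)C(=O)CC2)c1` has not yet been measured. It differs from compound 3 in one place: 2-hydroxy-5-methylphenyl in place of 3,4-dichlorophenyl on a carbon with a double bond to nitrogen.

Going by the values given here, two measured steps bear on this change. The step of a number 34.2 percentage points lower from compound 1 to compound 3 (beyond the scatter) shows that the 3,4-dichlorophenyl gives a markedly lower number than the 4-methoxyphenyl. Among the compounds with values here, the step of a number 18.4 percentage points lower from compound 2 to compound 3 (beyond the scatter) shows that it also gives a lower number than a 4-hydroxy-2-methylphenyl, a group built from the same atoms as the one that enters in compound 4, differing only in where the hydroxyl and methyl sit. Replacing the 3,4-dichlorophenyl by a hydroxy-methylphenyl is therefore expected to raise the number in this assay by a modest step, roughly the reverse of a number 18.4 percentage points lower from compound 2 to compound 3 (beyond the scatter); the expected step is a number 15.8 percentage points higher from compound 3 to compound 4 (beyond the scatter).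

Compound 4 is thus estimated to give 50%, with a range from 35% to 65%.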

Compound 4, a percentage reported as inhibition, in the whole organism at one dose (the size of the read-out at that dose, not a potency): 86.8%
Beside the measured number, compound 4's estimate is 36.8 percentage points below it, and the stated range ends below it.
By their numbers in this assay, from the lowest: compound 3; then compound 2; then compound 1; then compound 4.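

Going by these compounds alone, at the carbon with a double bond to nitrogen, this assay shows a number 52.6 percentage points higher from compound 3 to compound 4 (beyond the scatter), so this position can carry a far larger gain than the earlier compounds had indicated, and compound 4 stands highest of the four. The 2-hydroxy-5-methylphenyl and the 4-hydroxy-2-methylphenyl are not interchangeable, since the exchange gives a number 34.2 percentage points higher from compound 2 to compound 4 (beyond the scatter); where the hydroxyl and methyl sit on this ring therefore matters in this series, which compounds 1 to 3 could not reveal. Within the data shown here, the new group also surpasses the 4-methoxyphenyl, with a number 18.4 percentage points higher from compound 1 to compound 4 (beyond the scatter), so the best result among the earlier compounds was not the upper end for this position.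

No accompanying measurement accounts for the difference between the two hydroxy-methylphenyl groups. It remains open whether the hydroxyl or the methyl carries the gain on its own, whether an amine or a carboxylic acid in place of the hydroxyl would keep the number, and whether the order of these compounds would hold at other doses.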